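The compounds below may be only part of what the source reports. "The series", "measured", "known", "first", "only" and "open" are said of these compounds alone.

Measured compounds:
compound 1 `CCc1nc2nc(-c3ccccc3)cc(C(F)(F)F)c2c(=O)n1Cc1cn(CCC(F)(F)C(F)(F)C(F)(F)C(F)(F)C(F)(F)C(F)(F)C(F)(F)C(F)(F)F)nn1` — > 200 ug/mL
compound 2 `CCCCCCc1nc2nc(-c3ccccc3)cc(C(F)(F)F)c2c(=O)n1Cc1cn(CCC(F)(F)C(F)(F)C(F)(F)C(F)(F)C(F)(F)C(F)(F)C(F)(F)C(F)(F)F)nn1` — > 200 ug/mL
compound 3 `Cc1nc(OCc2cn(CCC(F)(F)C(F)(F)C(F)(F)C(F)(F)C(F)(F)C(F)(F)C(F)(F)C(F)(F)F)nn2)c2c(C(F)(F)F)cc(-c3ccccc3)nc2n1` — 22.4 ug/mL

Among the measured compounds shown here, in a functional assay on U-937 cells (Homo sapiens) for cytotoxicity, read by MTT assay, with a stated time of 24 h (a higher number here means a weaker inhibitor, a lower number a stronger inhibitor), compound 3 gives 22.4 ug/mL, the only number among the three. For compound 1 the value of > 200 ug/mL is a limit of this assay, not a number. For compound 2 the value of > 200 ug/mL is likewise a limit. The step from compound 1 to compound 2 is a step that the two limits leave unreadable from compound 1 to compound 2, given (the limit of > 200 ug/mL in this assay, at which 2 of the 3 values shown sit).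

Compound 4 `FC(F)(F)c1cc(-c2ccccc2)nc2nc(-c3ccccc3)nc(OCc3cn(CCC(F)(F)C(F)(F)C(F)(F)C(F)(F)C(F)(F)C(F)(F)C(F)(F)C(F)(F)F)nn3)c12` differs from compound 3 by phenyl in place of methyl on an aromatic carbon. For the measured compounds named here, no measured step bears on this change, and the only readable step is unreadable in size, so nothing points to a shift beyond the scatter in either direction. Compound 4 is therefore expected to give 30 ug/mL, within a range of 8 ug/mL to 150 ug/mL. This expectation corresponds to an estimated step of a 1.3-fold higher number from compound 3 to compound 4 (0.13 log units; within the scatter).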

Compound 4, half-maximal inhibitory concentration: 44.4 ug/mL
The estimate for compound 4 lay 1.5-fold (0.17 log units) below the measured number; the range from low to high includes it.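

In this assay, among the compounds shown here, phenyl in place of methyl on an aromatic carbon between two ring nitrogen atoms gives a 2.0-fold higher number from compound 3 to compound 4 (0.30 log units; within the scatter), the first step of readable size in this set. This position therefore accepts an aromatic ring in place of methyl with no shift beyond the scatter. Nothing measured here bears on the reason for this result.

The compounds shown leave open how an amine or a methoxy group would read at this position. They also leave open whether a longer chain there would stay within the scatter of compound 3.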